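This account rests on a few compounds, and the source may have more. Where it says the series, first, only, none or still open, it means among the compounds named here.

Two compounds share one core and differ only in a group on the outer aromatic ring. Compound 1 `N#Cc1ccc(-c2ccc(OS(N)(=O)=O)cc2)cc1` carries a cyano group, and in an assay on isolated protein for inhibition of Steryl-sulfatase (Homo sapiens), tested at 5 uM (on this read-out higher numbers stand for more inhibition at the one concentration tested (going by the name of the read-out) and lower numbers for less inhibition), compound 1 gives 44.2%. Compound 2 `COC(=O)c1ccc(-c2ccc(OS(N)(=O)=O)cc2)cc1` carries a methoxycarbonyl group in place of the cyano group, and in this assay compound 2 gives 44.2%. The step of no change at the digits printed from compound 1 to compound 2 (within the scatter) shows that swapping these two groups left the read-out where it was. Among the measured compounds shown here, compound 2 therefore stands level with compound 1, the only compound it can be compared with.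

Compound 3 `CCOC(=O)c1ccc(-c2ccc(OS(N)(=O)=O)cc2)cc1` is not yet measured. It differs from compound 2 by methyl in place of hydrogen on a saturated chain carbon bound to an oxygen next to a carbonyl group, so the methoxycarbonyl group becomes an ethoxycarbonyl group. For the measured compounds named here, no measured step concerns a change at this place; the single step available, from compound 1 to compound 2, changed the group itself and produced nothing beyond the scatter. With no evidence for a shift in either direction, the step of a number 0.2 percentage points lower from compound 2 to compound 3 (within the scatter) is expected to stay within the scatter. Compound 3 is estimated to give 44% in this assay, with a range from 30% to 58%.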

Compound 3, a percentage reported as inhibition, at one concentration (the size of the read-out at that concentration, not a potency): 53.4%
Compound 3: middle estimate off by 9.4 percentage points, on the low side; measured number inside the range.
By their numbers in this assay, from the lowest: compounds 1, 2 and 3 (each within the scatter of the next).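

In this assay, the methyl that turns methoxycarbonyl into ethoxycarbonyl gives a number 9.2 percentage points higher from compound 2 to compound 3 (within the scatter) and so adds one carbon to the ester chain without moving the read-out beyond what repeat measurements could produce. The comparison with the nitrile group gives a number 9.2 percentage points higher from compound 1 to compound 3 (within the scatter), so the cyano, methoxycarbonyl and ethoxycarbonyl groups cannot be told apart on this read-out, and none of them can be ranked above another. Nothing among the data shown offers an explanation for these numbers, and the small difference should not be read as a real trend.

A longer chain such as propoxycarbonyl or butoxycarbonyl could show whether the ester chain has any real influence on inhibition, while a carboxylic acid or a primary amide on the same aromatic carbon could show whether the ester itself matters. The compounds shown also leave open how these three compare in potency, since a percentage at one concentration gives the size of the effect at that concentration and nothing more.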